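A few compounds are considered here, and "the series" means these few. Any claim that something is new, unique, unknown or untested is made for them only; others in the source may bear on it.

In a functional assay on CHO cells for agonist activity at Alpha-1A adrenergic receptor (Homo sapiens), read by FLIPR and calcium flux (a lower number here means that less compound is needed, a higher number that more compound is needed for the effect), compound 2 `c1ccc(-c2cccc3c2CCC3c2ncc[nH]2)nc1` gives 1150 nM, the highest number among the three compounds measured. Compound 1 `Cc1oncc1-c1cccc2c1CCC2c1ncc[nH]1` gives 111 nM, and compound 3 `c1ccc2c(c1)CCCC2c1ncc[nH]1`, which has a different core and no aromatic substituent, gives 385 nM. The change leading to compound 4 `Cn1nccc1-c1cccc2c1CCC2c1ncc[nH]1` is 1-methyl-1H-pyrazol-5-yl in place of pyridin-2-yl on an aromatic carbon. Going by the values given here, the one measured step that bears on it is a 10-fold higher number from compound 1 to compound 2 (1.02 log units; beyond the scatter), in which a six-membered aromatic ring with one hetero atom took the place of a five-membered aromatic ring. Compound 4 brings back a five-membered aromatic ring, so a step of similar size in the opposite direction is expected, namely a 5.8-fold lower number from compound 2 to compound 4 (0.76 log units; beyond the scatter). Compound 4 is therefore estimated at 200 nM, with a likely range from 70 nM to 600 nM.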

Compound 4, half-maximal effective concentration: 278 nM
For compound 4 the middle estimate is 1.4-fold (0.14 log units) below the measured one, within the range that was stated.
By their numbers in this assay, from the lowest: compound 1; then compounds 4 and 3 (each within the scatter of the next); then compound 2.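

Putting 1-methyl-1H-pyrazol-5-yl in place of pyridin-2-yl gives a 4.1-fold lower number from compound 2 to compound 4 (0.62 log units; beyond the scatter) and shows that a second five-membered aromatic ring on this aromatic carbon also has a lower number than the six-membered one. The two five-membered rings are not interchangeable, since the other swap gives a 2.5-fold higher number from compound 1 to compound 4 (0.40 log units; beyond the scatter) and ring size alone therefore does not set the number. Nothing available explains either step. Going by these compounds, what an amine or a carboxylic acid on this aromatic carbon would do remains open, as does whether a plain phenyl ring would sit with pyridin-2-yl or with the five-membered rings.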